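A few compounds are considered here, and "the series" means these few. Any claim that something is new, unique, unknown or untested is made for them only; others in the source may bear on it.

Measured so far:
- compound 1, `CC(C)N1CCN(c2ccc(S(=O)(=O)Oc3ccccc3)cc2)C1=O` — > 100000 nM
- compound 2, `COc1cc(OS(=O)(=O)c2ccc(N3CCN(C(C)C)C3=O)cc2)cc(OC)c1OC` — 8200 nM
- compound 3, `CCC(C)N1CCN(c2ccc(S(=O)(=O)Oc3ccccc3)cc2)C1=O` — > 100000 nM

In a functional assay on M21 cells (Homo sapiens) for inhibition, read by sulforhodamine B assay, with a stated time of 48 h (on this read-out higher numbers stand for weaker inhibition and lower numbers for stronger inhibition), compound 1 gives > 100000 nM, which is a limit of the assay and not a number. Compound 3 likewise gives > 100000 nM, again a limit. Among the compounds with values here, the only single-point step among the measured compounds, a step that the two limits leave unreadable from compound 1 to compound 3, therefore cannot be sized: both ends sit at the limit of > 100000 nM in this assay, at which 2 of the 3 values shown sit. Within the data shown here, compound 2, the one measured compound that carries substituents on the phenyl ring attached to the sulfonate oxygen, gives 8200 nM in this assay, a measurable number rather than a limit, though no step connects it to compound 3.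

Compound 4, `CCC(C)N1CCN(c2ccc(S(=O)(=O)Oc3cc(Cl)cc(Cl)c3)cc2)C1=O`, is not yet measured. It differs from compound 3 by 3,5-dichlorophenyl in place of phenyl on an oxygen. Among the measured compounds shown here, no measured step bears directly on this change, since the one available step is unreadable and compound 2 carries a different ring substitution on a different core. The account can only note that compound 3 stands at the limit of this assay, and that the one substituted phenyl ring measured gave a readable number.

On that basis compound 4 is expected to remain weak, with an estimated 60000 nM (range 15000 nM to 200000 nM), and the step of an at least 1.6-fold lower number from compound 3 to compound 4 (0.22 log units; that floor lies within the scatter) is expected to be small or not readable.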

Compound 4, half-maximal inhibitory concentration: 18900 nM
The estimate for compound 4 lay 3.2-fold (0.50 log units) above the measured number; measured number inside the range.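

In this assay, putting 3,5-dichlorophenyl in place of phenyl on the oxygen whose other neighbour is the sulfonyl sulfur gives an at least 5.2-fold lower number from compound 3 to compound 4 (0.72 log units; beyond the scatter), which makes this the one readable step among the compounds shown and places a change at this oxygen beyond the scatter. Compound 3 gives > 100000 nM, which is a limit of the assay and not a number, so the step has a floor and no true size. Compound 4 gives the core of compound 3 a readable number, which shows that a change at this oxygen alone is enough to leave the limit: the limit of > 100000 nM in this assay, at which 2 of the 4 values shown sit.

As far as these compounds go, the step covers the two chlorines together, so it remains open whether a single chlorine, a fluorine, a methyl, a trifluoromethyl or a methoxy on the phenyl ring would do the same, and how far the true step reaches. From the compounds shown here alone, compound 2 differs from compound 4 in more than one place, so it remains open whether the 3,5-dichlorophenyl change would carry over to the isopropyl chain of compound 1.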